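Peroxide acid series: ring stereocentre inversion from compound 2

The compounds below may be only part of what the source reports. "The series", "measured", "known", "first", "only" and "open" are said of these compounds alone.

In a functional assay on HCC 2998 cells (Homo sapiens) for inhibition (a lower number here means a stronger inhibitor of growth, a higher number a weaker inhibitor of growth), compound 2 `C=C1CCC[C@H]2[C@](C)(CC[C@]3(C)CC[C@@H]([C@@H](C)C(=O)O)OO3)[C@@H](C)CC[C@]12C` gives 1030 nM, the lowest of the two numbers in hand. Its nearest neighbour is compound 3 `C=C1CCCC(C)(C)C1CC[C@@]1(C)CC[C@H]([C@@H](C)C(=O)O)OO1`, which gives 6780 nM in this assay, a gap beyond the scatter. Compound 1 `C=C1CCCC(C)(C)C1CC[C@]1(C)CC[C@@H]([C@@H](C)C(=O)O)OO1` gives > 10000 nM in this assay, which is a limit and not a number.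

Compound 4 `C=C1CCC[C@H]2[C@](C)(CC[C@]3(C)CC[C@H]([C@@H](C)C(=O)O)OO3)[C@@H](C)CC[C@]12C` is the next member. How it differs from compound 2: the two compounds have the same atoms and bonds and differ only in configuration as drawn: 1 of 7 stereo elements differ; a stereocentre at a saturated ring carbon is drawn S in compound 2 and R in compound 4

Going by the values given here, the only measured step that touches a change of configuration is an at least 1.4-fold lower number from compound 1 to compound 3 (0.16 log units; that floor lies within the scatter). That step is hard to read because the limit of > 10000 nM in this assay, at which 1 of the 3 values shown sits, and because of the fact that one of compounds 1 and 3 is drawn with a defined configuration and the other without, at the place where they differ, and it changes two stereo elements where the step to compound 4 changes one. It gives no sign that inversion at a saturated ring carbon moves the number by much in this series.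

The step from compound 2 to compound 4 is therefore expected to stay small, at most a modest loss, with an estimated size of a 1.9-fold higher number from compound 2 to compound 4 (0.29 log units; within the scatter). For compound 4 in this assay the estimate is 2000 nM, with a range from 700 nM to 6000 nM.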

Compound 4, concentration for 50% growth inhibition: 1550 nM
Estimate against measurement, compound 4: 1.3-fold (0.11 log units) above; the range from low to high includes it.
By their numbers in this assay, from the lowest: compounds 2 and 4 (each within the scatter of the next); then compound 3. At a limit, above all of these: compound 1.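

Inversion at this saturated ring carbon, one of the seven stereo elements of the pair, amounts in this assay to a 1.5-fold higher number from compound 2 to compound 4 (0.18 log units; within the scatter). Going by these compounds alone, this is the first reading of a single change of configuration with a number at both ends, and nothing else can account for the step, which stays within the scatter: the fact that compounds 2 and 4 differ only in the configuration as drawn The earlier step on configuration offered only a floor and changed two stereo elements, so at this position it is the new pair that shows that the configuration as drawn does not separate the two compounds in this assay.

On these data alone, whether the same holds for the other stereo elements of compound 2, or for the same inversion on the core of compound 3, remains open. Also open is whether the two configurations stay level in this read-out when the carboxylic acid is replaced by a methyl ester or a primary amide, as every compound shown carries the free carboxylic acid.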